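This account rests on a few compounds, and the source may have more. Where it says the series, first, only, none or still open, it means among the compounds named here.

Measured so far in an ADME assay on L02 cells (Homo sapiens) for inhibition, read by CCK-8 assay, with a stated time of 48 h; on this read-out lower numbers stand for stronger inhibition of growth and higher numbers for weaker inhibition of growth:
- compound 1 `Cc1ccccc1Nc1nc(NC2CC2)ncc1Cl`: > 100000 nM.
- compound 2 `Cc1ccccc1Nc1nc(Nc2ccc(N3CCN(C(=O)OC(C)(C)C)CC3)cc2)ncc1Cl`: 1750 nM.
- compound 3 `CN1CCN(c2ccc(Nc3ncc(Cl)c(Nc4ccccc4)n3)nc2)CC1`: 7990 nM.

For compound 1 the value is a limit of the assay, not a number. Of the two numbers, compound 3 sits highest; its nearest neighbour, compound 2, lies a good way lower, beyond the usual scatter, so compound 3 is the weaker growth inhibitor of the two.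

Compound 4 `CC(C)c1cccc(Nc2nc(Nc3ccc(N4CCN(C)CC4)cn3)ncc2Cl)c1` differs from compound 3 in one place: isopropyl in place of hydrogen on an aromatic carbon. Going by the values given here, no measured pair here shows what such an isopropyl brings, so the step is expected to be modest, leaning toward a lower number but not clearly beyond the scatter. The estimate for compound 4 is 4500 nM, from 1500 nM to 13000 nM. This means an expected step of a 1.8-fold lower number from compound 3 to compound 4 (0.25 log units; within the scatter).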

Compound 4, concentration for 50% growth inhibition: 12500 nM
Compound 4: middle estimate off by 2.8-fold (0.44 log units), on the low side, within the range that was stated.
By their numbers in this assay, from the lowest: compound 2; then compounds 3 and 4 (each within the scatter of the next). At a limit, above all of these: compound 1.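

In this assay, the change from phenyl to 3-isopropylphenyl gives a 1.6-fold higher number from compound 3 to compound 4 (0.19 log units; within the scatter), the first view of this position in the series. A group of this size on that aromatic carbon therefore leaves the number without a clear change. Nothing measured here accounts for how close the two values stay.

Still open, going by these compounds, is whether an amine, a carboxylic acid or a longer chain at the same place would move the number beyond the scatter. Isopropyl on the other carbons of this ring also remains untested here.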